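The source may hold more compounds than are shown below. What is called first, only, known or untested is meant among the compounds shown, and "the series" means these compounds.

Three measured compounds share a core and differ in the group carried on an amide-type nitrogen. In a functional assay on RPMI-8226 cells (Homo sapiens) for inhibition (on this read-out higher numbers stand for weaker inhibition and lower numbers for stronger inhibition), compound 1 (`CCOC(=O)CNC(=O)N1CC1C#N`) gives 25000 nM as its reading, compound 2 (`N#CC1CN1C(=O)Nc1ccc(Cl)c(Cl)c1`) gives 1100 nM and compound 3 (`CCCCNC(=O)N1CC1C#N`) gives 17000 nM on the same scale. Compound 3 lies within the usual scatter of compound 1, while compound 2 has a clearly lower number than compound 3, which means stronger inhibition.

The next compound, compound 4 (`CC(C)(C)NC(=O)N1CC1C#N`), is a close relative of compound 3. The change is tert-butyl in place of butyl on an amide-type nitrogen, so the same atoms are joined differently. Among the compounds with values here, no measured pair isolates a change of this kind, so its size can only be judged indirectly. Compound 1 at 25000 nM and compound 3 at 17000 nM carry quite different chains yet stay within the scatter of each other, and this supports expecting no step beyond the scatter in this assay here. Compound 2 at 1100 nM goes against that picture, so the range must stay wide. The expected step is a 1.2-fold higher number from compound 3 to compound 4 (0.07 log units; within the scatter) and it stays within the scatter. For compound 4 the estimated value is 20000 nM with an expected range from 7000 nM to 60000 nM on that scale.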

Compound 4, half-maximal inhibitory concentration: 120000 nM
The estimate for compound 4 lay 6.0-fold (0.78 log units) below the measured number; measured number above the stated range.
By their numbers in this assay, from the lowest: compound 2; then compounds 3 and 1 (each within the scatter of the next); then compound 4.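

In this assay this place, on an amide-type nitrogen whose other neighbour is the carbonyl carbon, proves sensitive to how the four carbons of the chain are joined and not only to how many there are: a 7.1-fold higher number from compound 3 to compound 4 (0.85 log units; beyond the scatter) comes with no atom gained or lost, and the higher number means weaker inhibition. Within the data shown here, the earlier compounds offered no pair differing in one place, so this is the first direct reading of a change at this position. Nothing available explains why tert-butyl gives weaker inhibition than butyl here, so the step stands as an observation only.

With only one branched chain among these compounds, it remains open whether a smaller branched group such as isopropyl, or a ring such as cyclohexyl, would fall closer to compound 3 or to compound 4. It is also unsettled how a longer straight chain such as hexyl would read, and how a plain phenyl ring without its two chlorines would compare with compound 2.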